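This account rests on a few compounds, and the source may have more. Where it says the series, first, only, none or still open, it means among the compounds named here.

Working notes on the series. Compound 1 `O=C(NCc1ccc(CNS(=O)(=O)c2ccccc2)cc1)c1ccc([N+](=O)[O-])cc1`, compound 2 `Cc1ccc(S(=O)(=O)NCc2ccc(CNC(=O)c3ccccc3)cc2)cc1` and compound 3 `O=C(NCc1ccc(CNS(=O)(=O)c2ccccc2)cc1)c1ccccc1` share one core and differ only in a single group on one of the two outer rings. In an assay on MDA-MB-231 cells for binding affinity to C-X-C chemokine receptor type 4 (Homo sapiens), read by immunofluorescence and microscopy, with stated times of 10 min and 30 min (on this read-out higher numbers stand for an effect only at larger amounts of compound and lower numbers for an effect already at smaller amounts), compound 3 gives 1 nM. In this assay compound 1 gives 100 nM. In this assay compound 2 gives > 1000 nM, which is a limit of the assay and not a number, so compound 2 stands at the edge of the measured range, (the limit of > 1000 nM in this assay, at which 1 of the 3 values shown sits). Both measured steps are large: a 100-fold lower number from compound 1 to compound 3 (2.00 log units; beyond the scatter) and an at least 1000-fold lower number from compound 2 to compound 3 (3.00 log units; beyond the scatter); only the first concerns the benzoyl ring.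

Compound 4 `COc1cccc(C(=O)NCc2ccc(CNS(=O)(=O)c3ccc(C)cc3)cc2)c1` is not yet measured and differs from compound 2 by methoxy in place of hydrogen on an aromatic carbon. Neither measured step is this exact change, but a 100-fold lower number from compound 1 to compound 3 (2.00 log units; beyond the scatter) shows that a group on the benzoyl ring can raise the number greatly, and compound 2 already sits at the limit. The expected step that the limit leaves unreadable from compound 2 to compound 4 is therefore no lowering beyond the scatter. Compound 4 is expected to give about 3000 nM in this assay, within 800 nM to 20000 nM, most probably reported again only as a limit.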

Compound 4, effective concentration (reported as EC, without a stated level of effect): 10 nM
The estimate for compound 4 lay 300-fold (2.48 log units) above the measured number, outside the stated range (below it).
By their numbers in this assay, from the lowest: compound 3; then compound 4; then compound 1. At a limit, above all of these: compound 2.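

In this assay, methoxy in place of hydrogen on the benzoyl ring, meta to a large group, gives an at least 100-fold lower number from compound 2 to compound 4 (2.00 log units; beyond the scatter), so a group on this ring can lower the number; the only earlier step on this ring, a 100-fold lower number from compound 1 to compound 3 (2.00 log units; beyond the scatter), had shown nitro raising it. Compound 2 gives > 1000 nM, which is a limit of the assay and not a number. The true size of the new step stays unknown because one end of it rests on that limit: the limit of > 1000 nM in this assay, at which 1 of the 4 values shown sits.

As far as these compounds go, whether methoxy has the same effect on the core of compound 3, without the methyl group on the other outer ring, stays open, as does its effect elsewhere on the benzoyl ring. Also open, from the compounds shown here alone, is how an amine, a carboxylic acid or a longer chain such as ethoxy would behave at this place.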